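Trimming the benzodioxin to a plain phenyl

The compounds below may be only part of what the source reports. "The series", "measured", "known", "first", "only" and "open" are said of these compounds alone.

Compound 1, `O=S(=O)(NCCCNCc1ccc(Cl)c(Cl)c1)c1cc(C(F)(F)F)cc(C(F)(F)F)c1`: in a functional assay on BXPC-3 cells (Homo sapiens) for inhibition, read by MTT assay, with a stated time of 72 h (on this read-out higher numbers stand for weaker inhibition of growth and lower numbers for stronger inhibition of growth), compound 1 gives 1400 nM.
Compound 2, `O=S(=O)(NCCCNCc1ccc(Cl)c(C(F)(F)F)c1)c1cc(C(F)(F)F)cc(C(F)(F)F)c1`: in this assay compound 2 gives 7800 nM.
Compound 3, `O=S(=O)(NCCCNCC1COc2ccccc2O1)c1cc(C(F)(F)F)cc(C(F)(F)F)c1`: in this assay compound 3 gives 1200 nM.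

Compound 3 and compound 1 lie within the usual scatter of each other, as the step of a 1.2-fold lower number from compound 1 to compound 3 (0.07 log units; within the scatter) shows, so neither can be called the stronger of the two. Compound 2 stands apart from both: the step of a 5.6-fold higher number from compound 1 to compound 2 (0.75 log units; beyond the scatter) and the step of a 6.5-fold lower number from compound 2 to compound 3 (0.81 log units; beyond the scatter) are each beyond the scatter, though modest in size.

Compound 4, `O=S(=O)(NCCCNCc1ccccc1)c1cc(C(F)(F)F)cc(C(F)(F)F)c1`, differs from compound 3 by phenyl in place of 2,3-dihydro-1,4-benzodioxin-2-yl on a saturated chain carbon bound to an amine nitrogen. Going by the values given here, no measured step makes exactly this change. The two steps that swap the group on that same chain carbon are the nearest guides: one, from compound 1 to compound 3, stays within the scatter, while the other, from compound 2 to compound 3, is modest. Swapping groups at this position therefore seems to move the number by a modest amount at most, with the direction not fixed by the data. For compound 4 the expected value in this assay is about 2400 nM, with a range from 900 nM to 7000 nM. This estimate means an expected step of a 2.0-fold higher number from compound 3 to compound 4 (0.30 log units; within the scatter), close to the edge of the scatter.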

Compound 4, concentration for 50% growth inhibition: 13000 nM
Estimate against measurement, compound 4: 5.4-fold (0.73 log units) below, and the stated range ends below it.
By their numbers in this assay, from the lowest: compounds 3 and 1 (each within the scatter of the next); then compounds 2 and 4 (each within the scatter of the next).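

Going by these compounds alone, the group on the saturated chain carbon bound to an amine nitrogen can matter more in this assay than the earlier compounds showed: there is an 11-fold higher number from compound 3 to compound 4 (1.03 log units; beyond the scatter), a large step, and a 9.3-fold higher number from compound 1 to compound 4 (0.97 log units; beyond the scatter), a modest step in the same direction. Phenyl does not simply stand in for every ring at this place, yet the pattern is not a plain split between substituted and unsubstituted phenyl, as a 1.7-fold higher number from compound 2 to compound 4 (0.22 log units; within the scatter) stays within the scatter, so compound 2, despite its chloro and trifluoromethyl groups, cannot be told apart from compound 4 and goes against any rule that substituents on the phenyl lower the number. Nothing measured here accounts for these differences.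

The compounds shown leave open how 3-chlorophenyl or 4-chlorophenyl would compare with phenyl and 3,4-dichlorophenyl, and so whether one chloro alone could account for the gap between compound 4 and compound 1. They also leave open whether a pyridyl or a cyclohexyl at this place would fall with compounds 1 and 3 or with compounds 2 and 4.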